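Difluoromethoxy added to the benzyl ring of compound 3

A few compounds are considered here, and "the series" means these few. Any claim that something is new, unique, unknown or untested is made for them only; others in the source may bear on it.

In a functional assay on RAW264.7 cells (Mus musculus) for inhibition, read by Griess assay, with stated times of 1 h and 24 h (a lower number here means a stronger inhibitor, a higher number a weaker inhibitor), compound 3 (`COc1cc(OC)c2c(c1)C(C(O)c1ccc(OCc3ccccc3)cc1)OC2=O`) gives > 10000 nM, which is a limit and not a number. Compound 1 (`COc1cc(OC)c2c(c1)C(C(O)c1ccc(O)cc1)OC2=O`) gives > 10000 nM, also a limit. For the measured compounds named here, compound 2 (`CCCCCCOc1ccc(C(O)C2OC(=O)c3c(OC)cc(OC)cc32)cc1`) is the only one with a number, 5360 nM.

Compound 4 (`COc1cc(OC)c2c(c1)C(C(O)c1ccc(OCc3ccc(OC(F)F)cc3)cc1)OC2=O`) carries difluoromethoxy in place of hydrogen on an aromatic carbon, para to a large group.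

Going by the values given here, two measured steps bear on this: a step that the two limits leave unreadable from compound 1 to compound 3, and an at least 1.8-fold higher number from compound 2 to compound 3 (0.27 log units; that floor lies within the scatter). Both change the group on the oxygen, and neither tests a substituent on the benzyl ring. No step beyond the scatter is therefore expected in this assay, in either direction.

For compound 4 the estimated value is 10000 nM, with an expected range of 3500 nM to 30000 nM. The expected change is a number no higher from compound 3 to compound 4 (the limit leaves the size open).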

Compound 4, half-maximal inhibitory concentration: 5030 nM
Beside the measured number, compound 4's estimate is 2.0-fold (0.30 log units) above it, within the range that was stated.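

In this assay, for the compounds shown here, difluoromethoxy on the benzyl ring gives the first number for a substituted benzyl on this oxygen: an at least 1.9-fold lower number from compound 3 to compound 4 (0.29 log units; that floor lies within the scatter), and an at least 1.9-fold lower number from compound 1 to compound 4 (0.29 log units; that floor lies within the scatter). Against the hexyl ether the result is a 1.1-fold lower number from compound 2 to compound 4 (0.03 log units; within the scatter), so the two groups cannot be told apart here. The true size of the other two steps stays unreadable, since each starts from a limit: the limit of > 10000 nM in this assay, at which 2 of the 4 values shown sit.

Still open, as far as these compounds go, is whether methoxy or chlorine at the same place on the benzyl ring would give a comparable number. Also open, from the compounds shown here alone, is what an amine or a carboxylic acid there would give.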